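Removing a Methoxy Group on Two Different Cores

A few compounds are considered here, and "the series" means these few. Any claim that something is new, unique, unknown or untested is made for them only; others in the source may bear on it.

Compound 1 `COc1ccc(-c2nc3ccccn3c2C(=O)/C=C\Nc2cnc3ccccc3c2)cc1` and compound 2 `O=C(/C=C\Nc1cnc2ccccc2c1)c1c(-c2ccccc2)nc2ccccn12` share one core, while compound 3 `COc1cc(N/C=C\C(=O)c2c(-c3ccc(Cl)cc3)nc3ccccn23)cc(OC)c1OC` is built on another; the difference between the two cores is not broken down here. Compound 4 `COc1cc(N/C=C\C(=O)c2c(-c3ccc(Cl)cc3)nc3ccccn23)cc(OC)c1` has not yet been measured. In a functional assay on MCF7 cells (Homo sapiens) for cytotoxicity, read by MTT assay, with a stated time of 48 h (a lower number here means a stronger inhibitor, a higher number a weaker inhibitor), compound 1 gives 15000 nM, compound 2 gives 5170 nM, and compound 3 gives 3390 nM. The step of a 2.9-fold lower number from compound 1 to compound 2 (0.46 log units; beyond the scatter) came from the change (hydrogen in place of methoxy on an aromatic carbon). The change leading to compound 4 is hydrogen in place of methoxy on an aromatic carbon; its place is additionally ortho to two methoxy groups (2 heavy atoms each), so this is the same kind of change, not the same one. Resting on the step of a 2.9-fold lower number from compound 1 to compound 2 (0.46 log units; beyond the scatter), and on compound 3 giving 3390 nM, a step of a 1.4-fold lower number from compound 3 to compound 4 (0.13 log units; within the scatter) is expected, with caution since the surroundings of the place differ. Compound 4 is estimated at 2500 nM, between 900 nM and 7000 nM.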

Compound 4, half-maximal inhibitory concentration: 13600 nM
Compound 4: middle estimate off by 5.4-fold (0.74 log units), on the low side; the measured number lies above the stated range.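

In this assay, putting hydrogen in place of methoxy gives a 4.0-fold higher number from compound 3 to compound 4 (0.60 log units; beyond the scatter), so the change that lowered the number on one core raises it on the other: the same change on two cores in this assay, a 2.9-fold lower number (0.46 log units; beyond the scatter) from compound 1 to compound 2 and a 4.0-fold higher number (0.60 log units; beyond the scatter) from compound 3 to compound 4, 12-fold (1.07 log units) apart, beyond the scatter of two such steps

On these two pairs, then, neither the size nor the direction of this step carries over from one core to the other. The pairs differ both in the core and in the surroundings of the place, which in compound 4 is ortho to two methoxy groups, so the data cannot separate these two differences or give a reason for the reversal.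

From the compounds shown here alone, it remains open how a fluorine atom, an amine or an ethoxy group at this place would behave on each core. Going by these compounds, it is also open whether the reversal would appear in further pairs.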